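This account rests on a few compounds, and the source may have more. Where it says the series, first, only, none or still open, it means among the compounds named here.

The measured compounds:
compound 1, `O=C(Nc1cccc(-c2oc3cc(-c4ccc(F)cc4)ccc3c(=O)c2O)c1)c1ccc(Cl)cc1`, which in a functional assay on GTL 16 cells for antiproliferative activity against GTL 16 cell line (Homo sapiens), read by CCK-8 assay, with a stated time of 72 h (on this read-out lower numbers stand for stronger inhibition and higher numbers for weaker inhibition), gives 9140 nM;
compound 2, `O=C(Nc1cccc(-c2oc3cc(-c4ccc(F)cc4)ccc3c(=O)c2O)c1)c1ccc(Br)cc1`, which in this assay gives 25400 nM.

Compound 2 stands at the higher of the two numbers. For the measured compounds named here, the only measured step joining it to another compound is a 2.8-fold higher number from compound 1 to compound 2 (0.44 log units; beyond the scatter), where bromo replaced chloro on an aromatic carbon of the (4-halophenyl)carbonyl group.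

Compound 3, `CCc1ccc(C(=O)Nc2cccc(-c3oc4cc(-c5ccc(F)cc5)ccc4c(=O)c3O)c2)cc1`, has not yet been measured. It differs from compound 2 in one place: ethyl in place of bromo on an aromatic carbon. The change is thus from a (4-bromophenyl)carbonyl to a (4-ethylphenyl)carbonyl group, on the aromatic carbon that is para to a large group.

Going by the values given here, no measured step covers a bromo-to-ethyl exchange; the step from compound 1 to compound 2 concerns two halogens only and does not speak directly to an ethyl group. With so little to go on, the expected step of a 1.3-fold lower number from compound 2 to compound 3 (0.10 log units; within the scatter) is set near zero, with a wide range around it. The account therefore ends here: compound 3 is expected to give about 20000 nM in this assay, somewhere between 6000 nM and 60000 nM, pending the measurement.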

Compound 3, half-maximal inhibitory concentration: 24600 nM
Beside the measured number, compound 3's estimate is 1.2-fold (0.09 log units) below it; low and high end bracket the measured number.
By their numbers in this assay, from the lowest: compound 1; then compounds 3 and 2 (each within the scatter of the next).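

In this assay, ethyl in place of bromo on the aromatic carbon para to a large group gives a 1.0-fold lower number from compound 2 to compound 3 (0.01 log units; within the scatter) and so leaves the read-out unmoved, even though the entering group has 2 carbon atoms where the leaving group has a single bromine. Compound 1 now stands apart from two groups rather than one: ethyl in place of chloro gives a 2.7-fold higher number from compound 1 to compound 3 (0.43 log units; beyond the scatter) and is about the same size as a 2.8-fold higher number from compound 1 to compound 2 (0.44 log units; beyond the scatter) at this position, so the lower number belongs to the chloro compound alone and the higher number is not confined to a halogen. Nothing available here accounts for the chloro compound standing apart or for bromo and ethyl reading alike.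

As far as these compounds go, whether an amine, a carboxylic acid, a methoxy group or a longer chain such as butyl on the same carbon would stay with bromo and ethyl, or move toward or past chloro, remains open. Also open, from the compounds shown here alone, is whether the separation of compound 1 from compound 2 and compound 3 would hold with plain hydrogen or fluoro at this carbon.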